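From Chloro to Fluoro on the Pendant Aryl Ring

The compounds below may be only part of what the source reports. "The series", "measured", "known", "first", "only" and "open" are said of these compounds alone.

Compound 1 `C=C(Br)C(=O)Nc1cccc(-c2cn3nc(-c4ccc(OC)c(OC)c4)sc3n2)c1` and compound 2 `C=C(Br)C(=O)Nc1cccc(-c2cn3nc(-c4ccc(Cl)cc4)sc3n2)c1` share one core and differ only in the aryl group hanging from it. Going by the values given here, in a functional assay on L1210 cells (Mus musculus) for inhibition, read by cell counting, with a stated time of 2 days (on this read-out higher numbers stand for weaker inhibition and lower numbers for stronger inhibition), compound 1 gives 42 nM, while compound 2 gives 1400 nM, the higher of the two numbers known so far; the step of a 33-fold higher number from compound 1 to compound 2 (1.52 log units; beyond the scatter) goes with 4-chlorophenyl in place of 3,4-dimethoxyphenyl on an aromatic carbon. Compound 3 `C=C(Br)C(=O)Nc1cccc(-c2cn3nc(-c4ccc(F)cc4)sc3n2)c1` takes the next step from compound 2: fluoro in place of chloro on an aromatic carbon. Among the compounds with values here, no measured step covers this exchange of one halogen for another; the only step known, a 33-fold higher number from compound 1 to compound 2 (1.52 log units; beyond the scatter), replaces the whole aryl group and says nothing about chloro against fluoro. One therefore expects the number for compound 3 to stay close to that of compound 2, with a step of a 1.1-fold higher number from compound 2 to compound 3 (0.03 log units; within the scatter) that is not expected to go beyond the scatter. Compound 3 is estimated at 1500 nM, within a range from 500 nM to 4500 nM.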

Compound 3, half-maximal inhibitory concentration: 250 nM
Estimate against measurement, compound 3: 6.0-fold (0.78 log units) above; measured number below the stated range.
By their numbers in this assay, from the lowest: compound 1; then compound 3; then compound 2.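

The halogen on this aryl ring matters: in this assay, the exchange of chloro for fluoro, a swap of one heavy atom for one heavy atom with no change in hydrogen-bond donors or acceptors, gives a 5.6-fold lower number from compound 2 to compound 3 (0.75 log units; beyond the scatter). The 4-fluorophenyl group closes only part of the gap to the 3,4-dimethoxyphenyl group, with a 6.0-fold higher number from compound 1 to compound 3 (0.77 log units; beyond the scatter), so compound 1 keeps the lowest number of the three, with its steps to both others beyond the scatter. Nothing at hand explains why the two halogens differ in this way.

From the compounds shown here alone, it remains open whether a single methoxy group, an amine or a trifluoromethyl group at the same place would fall nearer compound 1 or the halogen compounds. Also open, going by these compounds, is whether a bromo group would continue the order from fluoro to chloro.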